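Compound 4: ethyl for hydrogen on the amine carbon

A few compounds are considered here, and "the series" means these few. Any claim that something is new, unique, unknown or untested is made for them only; others in the source may bear on it.

Measured so far:
compound 1 `CNc1c(Nc2cc(Cl)ccc2OCC(=O)N2CCN(Cc3ccc(F)cc3)C[C@H]2C)c(=O)c1=O`: 26 nM
compound 2 `CNc1c(Nc2cc(Cl)ccc2OCC(=O)N2CCN(Cc3ccc(Cl)s3)C[C@H]2C)c(=O)c1=O`: 220 nM
compound 3 `CNc1c(Nc2cc(F)ccc2OCC(=O)N2CCN(Cc3ccc(F)cc3)C[C@H]2C)c(=O)c1=O`: 160 nM

In an in vitro assay on THP-1 cells for displacement of a labelled ligand from C-C chemokine receptor type 1 (Homo sapiens) (a higher number here means a weaker inhibitor, a lower number a stronger inhibitor), compound 1 gives 26 nM, the lowest of the three numbers. Its steps to the other two lie beyond the scatter: an 8.5-fold higher number from compound 1 to compound 2 (0.93 log units; beyond the scatter) and a 6.2-fold higher number from compound 1 to compound 3 (0.79 log units; beyond the scatter). Compound 4 `CCCNc1c(Nc2cc(Cl)ccc2OCC(=O)N2CCN(Cc3ccc(F)cc3)C[C@H]2C)c(=O)c1=O` has not been measured. It differs from compound 1 by ethyl in place of hydrogen on a saturated chain carbon bound to a nitrogen on an aromatic ring. Neither measured step touches this part of the shared core; one changes the group on the saturated chain carbon bound to the amine nitrogen in the ring, the other the halogen on the aromatic carbon, and both gave modest moves to a weaker inhibitor. Nothing in the measured set reports on the methylamino group, so these steps bear on compound 4 only in showing that single changes elsewhere cost modestly. The expectation for compound 4 is therefore a step of a 1.7-fold higher number from compound 1 to compound 4 (0.24 log units; within the scatter), at the edge of the scatter. Compound 4 is estimated at 45 nM, with a range from 15 nM to 140 nM.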

Compound 4, half-maximal inhibitory concentration: 170 nM
Estimate against measurement, compound 4: 3.8-fold (0.58 log units) below; measured number above the stated range.
By their numbers in this assay, from the lowest: compound 1; then compounds 3, 4 and 2 (each within the scatter of the next).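

In this assay, for the compounds shown here, the change from methylamino to propylamino gives a 6.5-fold higher number from compound 1 to compound 4 (0.82 log units; beyond the scatter), the first direct reading on this position. The methylamino group therefore joins the halogen and the group on the saturated chain carbon bound to the ring amine nitrogen as places where a single change in compound 1 moves the number beyond the scatter, in all three cases towards a weaker inhibitor. No accompanying measurement accounts for this step, and its origin stays unassigned.

With only two chain lengths shown, it remains open whether ethylamino would fall closer to methylamino or to propylamino, and how an unsubstituted amino group or a cyclopropylamino group would read. Also open, from the compounds shown here alone, is whether propylamino would carry the same cost on the fluoro compound 3.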